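Towards Compound 4 from a Compound at the Limit

The compounds below may be only part of what the source reports. "The series", "measured", "known", "first", "only" and "open" are said of these compounds alone.

Measured in a functional assay on DU-145 cells (Homo sapiens) for inhibition, read by trypan blue exclusion, with a stated time of 96 h; a higher number here means a weaker inhibitor of growth, a lower number a stronger inhibitor of growth:
Compound 1 `Cc1ccc(S(=O)(=O)/C(=C/c2ccc(O)c([N+](=O)[O-])c2)C(=O)c2ccc(Cl)cc2)cc1`: 25000 nM
Compound 2 `CN(C)c1ccc(/C=C(/SCc2ccc(Cl)cc2)C(=O)c2ccc(C(=O)O)cc2)cc1`: 1000 nM
Compound 3 `COc1cc(/C=C(\C(=O)c2ccc(Cl)cc2)S(=O)(=O)Cc2ccccc2Cl)cc(OC)c1`: > 100000 nM

Among the measured compounds shown here, of these three compounds, no two differ in only one place, so no measured step is available for comparison. Compound 3 gives only a limit, > 100000 nM, and no number. This is the limit of > 100000 nM in this assay, at which 1 of the 3 values shown sits.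

Compound 4 `O=C(/C(=C\c1ccc(O)c([N+](=O)[O-])c1)S(=O)(=O)Cc1ccccc1Cl)c1ccc(Cl)cc1` follows from compound 3 through a single change, 4-hydroxy-3-nitrophenyl in place of 3,5-dimethoxyphenyl on a double-bonded chain carbon bound to a double-bonded chain carbon.

The best guide to this change is compound 1, which also carries 4-hydroxy-3-nitrophenyl and gives 25000 nM, although it differs from compound 4 elsewhere as well. On that basis, the change is expected to move the series towards stronger inhibition of growth in this assay, by a margin beyond the usual scatter. Its exact size remains uncertain, since the starting point is a limit. The expected size of the change is an at least 5.0-fold lower number from compound 3 to compound 4 (0.69 log units; beyond the scatter). The estimated value for compound 4 is 20000 nM, with an expected range from 4000 nM to 100000 nM.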

Compound 4, concentration for 50% growth inhibition: 10000 nM
For compound 4 the middle estimate is 2.0-fold (0.30 log units) above the measured one; the measured number falls inside the stated range.
By their numbers in this assay, from the lowest: compound 2; then compound 4; then compound 1. At a limit, above all of these: compound 3.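

In this assay, among the compounds shown here, 4-hydroxy-3-nitrophenyl in place of 3,5-dimethoxyphenyl on a double-bonded chain carbon bound to a double-bonded chain carbon gives the first measured step at this position, an at least 10-fold lower number from compound 3 to compound 4 (1.00 log units; beyond the scatter), and it brings the 2-chlorobenzyl sulfonyl series from a limit to a readable number. As far as these compounds go, compound 3 gives only a limit, and the full size of this step therefore stays unknown: the limit of > 100000 nM in this assay, at which 1 of the 4 values shown sits. With 4-hydroxy-3-nitrophenyl held in place, 2-chlorobenzyl in place of 4-methylphenyl on a sulfonyl sulfur gives a 2.5-fold lower number from compound 1 to compound 4 (0.40 log units; beyond the scatter), which shows that the group on the sulfonyl sulfur also moves the number in this assay, though this rests on a single pair.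

The hydroxyl and nitro groups enter together in this change, and the compounds shown cannot tell how much of the step belongs to each; a phenyl ring carrying only a hydroxyl group or only a nitro group would separate them. From the compounds shown here alone, it also remains open how the number responds on the sulfonyl sulfur to a longer chain, such as 2-chlorophenethyl, in place of 2-chlorobenzyl.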